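Oxygen in the Ring: From Cyclopentyl to Oxolanyl

The source may hold more compounds than are shown below. What is called first, only, known or untested is meant among the compounds shown, and "the series" means these compounds.

Within the data shown here, the two compounds measured so far share one core and differ only in the ring attached to a nitrogen on an aromatic ring. Compound 1 `CCCn1c(-c2ccccc2)nc2c(NC3CCC3)ncnc21` carries a cyclobutyl there; in an assay on CHO cells for displacement of a labelled ligand from adenosine receptor A1 (Homo sapiens), read by scintillation counting, with a stated time of 3 h (a lower number here means a stronger inhibitor, a higher number a weaker inhibitor), compound 1 gives 15 nM. Compound 2 `CCCn1c(-c2ccccc2)nc2c(NC3CCCC3)ncnc21` carries a cyclopentyl, and in this assay compound 2 gives 10 nM. The step of a 1.5-fold lower number from compound 1 to compound 2 (0.18 log units; within the scatter) is within the scatter, so compound 2 stands with the lower of the two numbers but cannot be called stronger than compound 1.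

Compound 3 `CCCn1c(-c2ccccc2)nc2c(NC3CCOC3)ncnc21` keeps the ring size of compound 2 and changes one ring atom: oxolan-3-yl in place of cyclopentyl on a nitrogen on an aromatic ring. Among the measured compounds shown here, the single measured step concerns ring size only and says nothing about putting an oxygen into the ring, so it bears on this change only loosely. With no direct evidence, the expectation for compound 3 in this assay is a modest step toward a higher number, a 2.5-fold higher number from compound 2 to compound 3 (0.40 log units; beyond the scatter), possibly not beyond the scatter. Compound 3 is therefore estimated at 25 nM, with a range from 8 nM to 80 nM.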

Compound 3, inhibition constant: 25 nM
Estimate against measurement, compound 3: no gap at the digits printed; the range from low to high includes it.
By their numbers in this assay, from the lowest: compounds 2, 1 and 3 (each within the scatter of the next, the first and the last beyond it).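

Keeping the ring size and changing a single ring atom is enough to move the result at this position: with oxolan-3-yl in place of cyclopentyl on the nitrogen, this assay shows a 2.5-fold higher number from compound 2 to compound 3 (0.40 log units; beyond the scatter), the first step in this small set to lie beyond the scatter, though still a modest one. The same group set against cyclobutyl gives a 1.7-fold higher number from compound 1 to compound 3 (0.22 log units; within the scatter), which lies within the scatter, so compound 1 and compound 3 cannot be told apart here, and a ring with an oxygen remains compatible with a number in the same range as the smaller carbon ring. The change brings 1 hydrogen-bond acceptor into the ring, but no supporting data link that feature, or any other, to the shift seen here.

On these data alone, it remains open whether another ring atom, such as the nitrogen of a pyrrolidin-3-yl group, would give a step of similar size, or whether the oxygen would count for the same in a larger ring such as oxan-4-yl. An open chain carrying an oxygen, such as 2-methoxyethyl, would also test whether a ring is needed at all on this nitrogen.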